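A ring swap on a compound at the limit

A few compounds are considered here, and "the series" means these few. Any claim that something is new, unique, unknown or untested is made for them only; others in the source may bear on it.

In a functional assay on MDA-MB-231 cells (Homo sapiens) for antiproliferative activity, read by MTT assay, with a stated time of 24 h (on this read-out lower numbers stand for stronger inhibition and higher numbers for weaker inhibition), compound 1 (`CCCCOc1ccc(C(=O)NNC(=O)c2ccc(NS(=O)(=O)c3cnc(O)nc3O)cc2)cc1`) gives 11900 nM as its reading. Compound 2 (`Cc1ccc(C(=O)NNC(=O)c2ccc(NS(=O)(=O)c3cnc(O)nc3O)cc2)cc1`) gives > 20000 nM as a limit, not a number (the limit of > 20000 nM in this assay, at which 1 of the 2 values shown sits). Compound 3 (`O=C(NNC(=O)c1cccc(Cl)c1)c1ccc(NS(=O)(=O)c2cnc(O)nc2O)cc1`) has 3-chlorophenyl in place of 4-methylphenyl on a carbonyl carbon. Among the compounds with values here, the one measured step is an at least 1.6-fold higher number from compound 1 to compound 2 (0.22 log units; that floor lies within the scatter) and it concerns methyl in place of butoxy, so it sets no firm size for this change. In this assay the expected step is therefore none beyond the scatter, with an at least 1.0-fold lower number from compound 2 to compound 3 (0.02 log units; that floor lies within the scatter) as the estimate. Compound 3 is estimated at 19000 nM within a range of 9000 nM to 40000 nM and may also read as a limit.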

Compound 3, half-maximal inhibitory concentration: 4160 nM
The estimate for compound 3 lay 4.6-fold (0.66 log units) above the measured number, outside the stated range (below it).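

In this assay, the group on this carbonyl carbon can move the reading beyond the scatter, which the earlier pair could not show: 3-chlorophenyl in place of 4-methylphenyl gives an at least 4.8-fold lower number from compound 2 to compound 3 (0.68 log units; beyond the scatter). The same group in place of 4-butoxyphenyl gives a 2.9-fold lower number from compound 1 to compound 3 (0.46 log units; beyond the scatter). The first of these steps is a floor and not a full size, as compound 2 stands at a limit: the limit of > 20000 nM in this assay, at which 1 of the 3 values shown sits.

Both the substituent and its place on the ring differ in these swaps, and the compounds shown do not separate the two. Going by these compounds, how 4-chlorophenyl or 3-methylphenyl would read on this carbonyl carbon remains open.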